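Dithiocarbamate amine variation on the shared benzamide core

A few compounds are considered here, and "the series" means these few. Any claim that something is new, unique, unknown or untested is made for them only; others in the source may bear on it.

Compound 3 `CN(Cc1cccnc1)C(=S)SCc1ccc(C(=O)Nc2ccccc2N)cc1` stands lowest of the three numbers in a functional assay on A-375 cells (Homo sapiens) for antiproliferative activity, read by CCK-8 assay, with a stated time of 72 h, tested at 2 uM (on this read-out lower numbers stand for a weaker effect and higher numbers for a stronger effect at the one concentration tested), giving 39.4%. Compound 1 `CC1CCCCN1C(=S)SCc1ccc(C(=O)Nc2ccccc2N)cc1` gives 42.5%, and compound 2 `CCN(Cc1ccncc1)C(=S)SCc1ccc(C(=O)Nc2ccccc2N)cc1` gives 67.2%. The step of a number 3.1 percentage points lower from compound 1 to compound 3 (within the scatter) lies within the scatter, while a number 27.8 percentage points lower from compound 2 to compound 3 (beyond the scatter) is beyond it.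

Compound 4 `Nc1ccccc1NC(=O)c1ccc(CSC(=S)N2CCCc3ccccc32)cc1` differs from compound 3 by 1,2,3,4-tetrahydroquinolin-1-yl in place of methyl((pyridin-3-yl)methyl)amino on a thiocarbonyl carbon. The relevant step is that from compound 1 to compound 3: a cyclic amine on the thiocarbonyl carbon, as in compound 1, gave a number within the scatter of compound 3, so the return to a cyclic amine in compound 4 is expected to give a number 5.6 percentage points higher from compound 3 to compound 4 (within the scatter), a change within the scatter. For compound 4 the expected value in this assay is 45%, in the range 25% to 65%.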

Compound 4, a percentage reported as inhibition, at one concentration (the size of the read-out at that concentration, not a potency): 26.5%
For compound 4 the middle estimate is 18.5 percentage points above the measured one; the measured number falls inside the stated range.
By their numbers in this assay, from the lowest: compound 4; then compounds 3 and 1 (each within the scatter of the next); then compound 2.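

The 1,2,3,4-tetrahydroquinolin-1-yl group on the thiocarbonyl carbon gives the lowest number of the four, with a number 12.9 percentage points lower from compound 3 to compound 4 (beyond the scatter) and a number 16 percentage points lower from compound 1 to compound 4 (beyond the scatter) and a number 40.7 percentage points lower from compound 2 to compound 4 (beyond the scatter). A cyclic amine at this position therefore does not by itself hold the level of compound 1. Nothing available explains these steps.

Still open, from the compounds shown here alone, is whether the ethyl or the pyridin-4-yl part of compound 2 carries its higher number. Also open, going by these compounds, is whether a morpholin-4-yl group or a propyl chain in place of that ethyl would keep it.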